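Swapping the five-membered ring on a shared core

The source may hold more compounds than are shown below. What is called first, only, known or untested is meant among the compounds shown, and "the series" means these compounds.

In a functional assay on the whole organism (strain NMRI) with Mus musculus as the target, with a stated time of 60 min, at a dose of 5 mg/kg by the intraperitoneal route (a higher number here means a stronger effect of the compound at the dose given, a lower number a weaker effect), compound 1 `CSc1nnc(Cc2ccc(Cl)cc2Oc2ccccc2Cl)[nH]1` gives 125%. Compound 2 `Clc1ccc(Cc2nnc(SCc3ccccc3)[nH]2)c(Oc2ccccc2Cl)c1` gives 113%, and compound 3 `Nc1nnc(Cc2ccc(Cl)cc2Oc2ccccc2Cl)o1` gives 125%. Compound 3 thus stands level with compound 1 at the digits shown, together the highest of the three numbers; its furthest neighbour is compound 2. Compound 4 `CCOc1nnc(Cc2ccc(Cl)cc2Oc2ccccc2Cl)[nH]1` differs from compound 3 in one place: a group of 8 heavy atoms (4 carbon, 3 nitrogen, 1 oxygen; one five-membered aromatic ring with 3 hetero atoms) in place of a group of 6 heavy atoms (2 carbon, 3 nitrogen, 1 oxygen; one five-membered aromatic ring with 3 hetero atoms), on a saturated chain carbon bound to an aromatic carbon. Going by the values given here, two measured steps bear on this. Exchanging one five-membered ring for another gave no change at the digits printed from compound 1 to compound 3 (within the scatter), while a phenyl entering on the saturated chain carbon bound to a sulfur gave a number 12 percentage points lower from compound 1 to compound 2 (beyond the scatter). Because the ring exchange no change at the digits printed from compound 1 to compound 3 (within the scatter), only a small step is expected, a number 5 percentage points lower from compound 3 to compound 4 (within the scatter). Compound 4 is therefore estimated at 120%, within 100% to 135%.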

Compound 4, a percentage reported as activity, at one dose (the size of the read-out at that dose, not a potency): 120%
For compound 4 middle estimate and measured number coincide at the digits printed; low and high end bracket the measured number.
By their numbers in this assay, from the lowest: compounds 2, 4, 1 and 3 (each within the scatter of the next, the first and the last beyond it).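

Ethoxy on the ring at this position, a saturated chain carbon bound to an aromatic carbon, gives in this assay a number 5 percentage points lower from compound 3 to compound 4 (within the scatter) against the 5-amino-1,3,4-oxadiazol-2-yl group. Ethoxy in place of methylsulfanyl gives a number 5 percentage points lower from compound 1 to compound 4 (within the scatter), and ethoxy in place of benzylsulfanyl gives a number 7 percentage points higher from compound 2 to compound 4 (within the scatter). So this new oxygen-linked group stays within the scatter of all three earlier compounds, including compound 2, which lay beyond the scatter of compounds 1 and 3.

Nothing available explains these small steps. Going by these compounds, what a carboxylic acid or a longer chain such as butoxy would give in place of ethoxy remains open.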